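Bromo on the fused ring, repeated on a second core

A few compounds are considered here, and "the series" means these few. Any claim that something is new, unique, unknown or untested is made for them only; others in the source may bear on it.

Compound 1 `COc1ccc(C2CC(c3ccc4ccccc4c3)=NN2C2=NC(=O)/C(=C3\C(=O)Nc4ccccc43)S2)cc1` gives 12600 nM in a functional assay on cells (Cancer cell lines, Homo sapiens) for cytotoxicity, read by sulforhodamine B assay, with a stated time of 48 h; on this read-out higher numbers stand for weaker inhibition of growth and lower numbers for stronger inhibition of growth. Compound 2 `COc1ccc(C2CC(c3ccc4ccccc4c3)=NN2C2=NC(=O)/C(=C3\C(=O)Nc4ccc(Br)cc43)S2)cc1` differs from it only by bromo in place of hydrogen on an aromatic carbon, and in this assay compound 2 gives 210 nM. That single change made a 60-fold lower number from compound 1 to compound 2 (1.78 log units; beyond the scatter), the one large movement seen so far in the series.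

Compound 3 `CN(C)c1ccc(C2CC(c3ccccc3)=NN2C2=NC(=O)/C(=C3\C(=O)Nc4ccccc43)S2)cc1` carries a second core; the difference between the two cores is not broken down here. In this assay compound 3 gives 3240 nM, which places it between compound 1 and compound 2.

Compound 4 `CN(C)c1ccc(C2CC(c3ccccc3)=NN2C2=NC(=O)/C(=C3\C(=O)Nc4ccc(Br)cc43)S2)cc1` has not yet been measured. It differs from compound 3 by bromo in place of hydrogen on an aromatic carbon, the same change, at the same place, as from compound 1 to compound 2. For compound 4 a step of about a 27-fold lower number from compound 3 to compound 4 (1.43 log units; beyond the scatter) is expected, somewhat more cautious than the precedent because a 60-fold lower number from compound 1 to compound 2 (1.78 log units; beyond the scatter) is a single pair on another core. The estimate for compound 4 in this assay is therefore 120 nM, with a plausible range from 30 nM to 600 nM.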

Compound 4, concentration for total growth inhibition: 450 nM
Beside the measured number, compound 4's estimate is 3.8-fold (0.57 log units) below it; measured number inside the range.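

On the core of compound 3, bromo in place of hydrogen on an aromatic carbon again lowers the number in this assay, with a 7.2-fold lower number from compound 3 to compound 4 (0.86 log units; beyond the scatter), so on these two pairs the direction of the change carries from one core to the other. The size of the step does not carry over unchanged: the same change on two cores in this assay, a 60-fold lower number (1.78 log units; beyond the scatter) from compound 1 to compound 2 and a 7.2-fold lower number (0.86 log units; beyond the scatter) from compound 3 to compound 4, 8.3-fold (0.92 log units) apart, beyond the scatter of two such steps Compound 1 and compound 3 differ in more than one place, and the two pairs do not show which of those differences goes with the gap, nor whether the same direction would hold on any further core.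

As far as these compounds go, whether the lower number is tied to bromo itself, or would also follow with chloro, a methyl group or an amine on the same aromatic carbon, stays open. Also open, from the compounds shown here alone, is how the step behaves on a core that differs from the core of compound 3 in one place only, which would narrow down where the gap arises.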